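From 3,5-dichlorobenzyl to 4-chlorobenzyl

A few compounds are considered here, and "the series" means these few. Any claim that something is new, unique, unknown or untested is made for them only; others in the source may bear on it.

Of the compounds shown here, two that share a core have been measured so far. In a functional assay on HuT78 cells (Homo sapiens) for inhibition, read by sulforhodamine B assay, with a stated time of 72 h (a higher number here means a weaker inhibitor of growth, a lower number a stronger inhibitor of growth), compound 1 (`O=C(NO)c1cnc(N2C[C@H]3CN(C(=O)c4ccc5ccccc5c4)C[C@H]3C2)nc1`) gives 200 nM and compound 2 (`O=C(NO)c1cnc(N2C[C@H]3CN(Cc4cc(Cl)cc(Cl)c4)C[C@H]3C2)nc1`) gives 202 nM and so stands level with compound 1, since the two numbers lie within the scatter of each other.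

Compound 3 (`O=C(NO)c1cnc(N2C[C@H]3CN(Cc4ccc(Cl)cc4)C[C@H]3C2)nc1`) has not yet been measured. It carries 4-chlorophenyl in place of the 3,5-dichlorophenyl of compound 2, on a saturated chain carbon bound to an amine nitrogen in a ring (4-chlorophenyl in place of 3,5-dichlorophenyl on a saturated chain carbon bound to an amine nitrogen in a ring). Among the compounds with values here, no measured pair differs in just one place, so the data offer no direct guide to this change. The only hint is indirect: compound 1 at 200 nM and compound 2 at 202 nM carry different groups on the core, yet their values sit within the scatter. A small change is therefore expected, perhaps toward a slightly higher number. The expected step is a 1.2-fold higher number from compound 2 to compound 3 (0.09 log units; within the scatter) and it should stay within the scatter. Compound 3 is estimated at 250 nM with an expected range from 90 nM to 700 nM as the likely span.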

Compound 3, concentration for 50% growth inhibition: 190 nM
Compound 3: the middle estimate sits 1.3-fold (0.12 log units) above what was measured, within the range that was stated.
By their numbers in this assay, from the lowest: compounds 3, 1 and 2 (each within the scatter of the next).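

Within the data shown here, this is the first direct comparison at this position: in this assay the change from 3,5-dichlorobenzyl to 4-chlorobenzyl gives a 1.1-fold lower number from compound 2 to compound 3 (0.03 log units; within the scatter) and so makes no measurable difference. The 3,5-dichlorophenyl group carries two chlorine atoms and the 4-chlorophenyl group only one, so on the saturated chain carbon bound to an amine nitrogen in a ring, this growth read-out does not tell these two groups apart. No other measurement bears on this result, so the data offer no explanation for the two groups reading alike.

The compounds shown leave open what a plain benzyl group with no chlorine would give, or a benzyl group carrying a methoxy group or a carboxylic acid where the chlorine of compound 3 sits. They also leave open whether the two parts of this change, the loss of one chlorine and the new place of the other, would each leave the number unchanged if taken alone, or whether larger effects happen to cancel here.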